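A Different Amine Tail on Compound 1

The compounds below may be only part of what the source reports. "The series", "measured", "known", "first", "only" and "open" are said of these compounds alone.

In a functional assay on A549 cells (Homo sapiens) for antiproliferative activity, read by MTT assay, with a stated time of 48 h (a lower number here means a stronger inhibitor, a higher number a weaker inhibitor), compound 1 `O=c1cc(-c2ccccc2)oc2cc(OCc3ccccc3)c(OCCCN3CCCC3)c(O)c12` gives 1400 nM, the lowest of the two plain numbers, and compound 2 `COc1cc2oc(-c3ccccc3)cc(=O)c2c(O)c1OCCCN1CCCC1` gives 6000 nM after the step of a 4.3-fold higher number from compound 1 to compound 2 (0.63 log units; beyond the scatter). Compound 3 `O=c1cc(-c2ccccc2)oc2cc(O)c(OCCCN3CCCC3)c(O)c12` reaches only a limit, > 100000 nM. The steps of an at least 71-fold higher number from compound 1 to compound 3 (1.85 log units; beyond the scatter) and an at least 16-fold higher number from compound 2 to compound 3 (1.22 log units; beyond the scatter) both run into that limit (the limit of > 100000 nM in this assay, at which 1 of the 3 values shown sits). Compound 4 `CCN(CC)CCCCOc1c(OCc2ccccc2)cc2oc(-c3ccccc3)cc(=O)c2c1O` differs from compound 1 by (diethylamino)methyl in place of pyrrolidin-1-yl on a saturated chain carbon, three bonds along the chain from an oxygen on an aromatic ring. Going by the values given here, none of the measured steps touches the amine end of the chain; each of them alters a group on a ring oxygen. The writer therefore expects the step from compound 1 to compound 4 to stay within the scatter, a 1.1-fold higher number from compound 1 to compound 4 (0.03 log units; within the scatter). The estimate for compound 4 in this assay is 1500 nM, expected to fall between 500 nM and 5000 nM.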

Compound 4, half-maximal inhibitory concentration: 1800 nM
The estimate for compound 4 lay 1.2-fold (0.08 log units) below the measured number; the measured number falls inside the stated range.
By their numbers in this assay, from the lowest: compounds 1 and 4 (each within the scatter of the next); then compound 2. At a limit, above all of these: compound 3.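

In this assay, going by these compounds alone, all the earlier steps altered a group on a ring oxygen, whereas this one changes the amine end of the chain, and the result stays within the scatter: a 1.3-fold higher number from compound 1 to compound 4 (0.11 log units; within the scatter). For compound 1, then, a 3-(pyrrolidin-1-yl)propyl tail and a 4-(diethylamino)butyl tail read alike, although the ring is gone and the chain is longer. No measurement shown bears on why they do. The compounds shown leave open whether a morpholine, a primary amine or a shorter chain would also read alike.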